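Removing the N-benzyl group: compound 3 to compound 4

This account rests on a few compounds, and the source may have more. Where it says the series, first, only, none or still open, it means among the compounds named here.

Measured compounds:
Compound 1 `CC(=O)n1cc(/C=C(/C(=O)O)c2ccccc2)c2cc(OCc3ccccc3)ccc21`: "not determined" (no result reported)
Compound 2 `COc1ccc(/C(=C\c2c[nH]c3ccc(OCc4ccccc4)cc23)C(=O)O)cc1`: > 100000 nM
Compound 3 `COc1ccc(Cn2cc(/C=C(/C(=O)O)c3ccccc3)c3cc(OCc4ccccc4)ccc32)cc1`: "not determined" (no result reported)

In a functional assay on Caco-2 cells (Homo sapiens) for cytotoxicity, read by MTT assay, with a stated time of 72 h (on this read-out lower numbers stand for stronger inhibition and higher numbers for weaker inhibition), compound 3 has no number of its own. Of the three entries shown, one is a limit and one more carries no value, so compound 3 cannot be placed against the others by its own result. Compound 2 gives only a limit in this assay, recorded as > 100000 nM, and that limit is the sole quantitative anchor here (the limit of > 100000 nM in this assay, at which 1 of the 3 values shown sits).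

Compound 4 `O=C(O)/C(=C/c1c[nH]c2ccc(OCc3ccccc3)cc12)c1ccccc1` differs from compound 3 in one place: hydrogen in place of 4-methoxybenzyl on an aromatic nitrogen. Within the data shown here, no measured pair shows what such a step does in this assay, so its size and direction cannot be read from the data. Among the measured compounds shown here, the one compound that shares the unsubstituted nitrogen with compound 4 is compound 2, and it reaches only a limit. Compound 4 is therefore expected to sit in the same weak region, with an estimated value of 150000 nM and a range from 30000 nM to 500000 nM, most likely reported again as a limit.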

Compound 4, half-maximal inhibitory concentration: 41600 nM
For compound 4 the middle estimate is 3.6-fold (0.56 log units) above the measured one; measured number inside the range.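

In this assay, compound 4 is the only compound shown with a single number, so a value within measurable reach is seen here with hydrogen on the aromatic nitrogen. The first readable step concerns a different place, the aromatic carbon that carries methoxy in the other compound with this unsubstituted nitrogen: hydrogen in place of methoxy there gives an at least 2.4-fold lower number from compound 2 to compound 4 (0.38 log units; beyond the scatter). The true size of that step remains unknown, since compound 2 gives only a limit: the limit of > 100000 nM in this assay, at which 1 of the 4 values shown sits.

Among these compounds, compound 1 and compound 3 carry no value, so no step that changes the group on the aromatic nitrogen can be read. On these data alone, what a methyl group on that nitrogen would do stays open, as does the effect of a chlorine or a hydroxyl group on that aromatic carbon.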